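A few compounds are considered here, and "the series" means these few. Any claim that something is new, unique, unknown or untested is made for them only; others in the source may bear on it.

Measured in an ADME assay on DU-145 cells (Homo sapiens) for cytotoxicity, read by MTT assay, with a stated time of 72 h; on this read-out higher numbers stand for weaker inhibition and lower numbers for stronger inhibition:
- Compound 1 `C=CCOc1cc(C2=C(c3cc(OC)c(OC)c(OC)c3)C(=O)C(O)C2)ccc1OC`: > 100 ug/mL
- Compound 2 `COCOc1cc(C2=C(c3cc(OC)c(OC)c(OC)c3)C(=O)CC2O[SiH2]C(C)(C)C)ccc1OC`: 34 ug/mL

Compound 1 stands at > 100 ug/mL in this assay, and this reading is a limit of the assay, not a number. Compound 3 `COc1ccc(C2=C(c3cc(OC)c(OC)c(OC)c3)C(=O)C(O)C2)cc1OC(C)C` keeps the core of compound 1 but carries isopropyl in place of allyl on an oxygen on an aromatic ring. Among the compounds with values here, no measured pair shows what this swap does. The expectation in this assay is therefore no change beyond the usual scatter, with the estimated step being a step that the limit leaves unreadable from compound 1 to compound 3. For compound 3 the estimated value is 110 ug/mL, with an expected range from 50 ug/mL to 220 ug/mL.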

Compound 3, half-maximal inhibitory concentration: > 100 ug/mL
Compound 3 gave a limit, no number (the forecaster's own chance of this, stated with the estimate: 60%); the middle value does not contradict the limit.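

Compound 1 and compound 3 both give a limit of the assay rather than a number, so no step can be read between them: the limit of > 100 ug/mL in this assay, at which 2 of the 3 values shown sit.

The compounds shown leave open whether isopropyl in place of allyl changes cytotoxicity at all.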